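The source may report more compounds than this note shows. Statements on the series, on what has been measured and on what is new or still open speak of the compounds shown alone.

Compound 1 `Cc1cc(Cl)c(S(C)(=O)=O)cc1C(=O)N=C(N)N` gives 25 nM.
Compound 2 `Cc1cc(C)c(S(C)(=O)=O)cc1C(=O)N=C(N)N` gives 11 nM.

Among the measured compounds shown here, in a functional assay for inhibition of sodium/hydrogen exchanger (Oryctolagus cuniculus) (a higher number here means a weaker inhibitor, a lower number a stronger inhibitor), compound 1 stands with the higher of the two numbers; its only neighbour is compound 2, reached by a 2.3-fold lower number from compound 1 to compound 2 (0.36 log units; beyond the scatter). Compound 3 `CS(=O)(=O)c1cc(C(=O)N=C(N)N)ccc1Cl` differs from compound 1 in a single place: hydrogen in place of methyl on an aromatic carbon. For the measured compounds named here, no measured step removes this methyl group; the one step that has been measured, from compound 1 to compound 2, swaps a chloro for a methyl and not the methyl that leaves here, and it was modest in size. It therefore bears only loosely on the change to compound 3, and the data give no direct guide. The expectation is that removing one small group from the shared core shifts this assay little, with a slight rise in the number being the more likely direction. Compound 3 is estimated at 40 nM, between 15 nM and 110 nM, which means an expected 1.6-fold higher number from compound 1 to compound 3 (0.20 log units; within the scatter).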

Compound 3, half-maximal inhibitory concentration: 380 nM
Compound 3: the middle estimate sits 9.5-fold (0.98 log units) below what was measured, and the stated range ends below it.
By their numbers in this assay, from the lowest: compound 2; then compound 1; then compound 3.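

In this assay the methyl group, on the aromatic carbon ortho to a group of 6 heavy atoms, proves far from neutral: replacing it with hydrogen gives a 15-fold higher number from compound 1 to compound 3 (1.18 log units; beyond the scatter) and that is a much larger step than a 2.3-fold lower number from compound 1 to compound 2 (0.36 log units; beyond the scatter) at the chloro group. So among these three compounds, losing a single carbon atom at this place counts for more than exchanging chloro for methyl on the same ring. Nothing measured here explains why the number climbs so steeply.

As far as these compounds go, with only methyl and hydrogen compared at this place, it stays open whether an ethyl, a methoxy or an amino group would match methyl or do worse. From the compounds shown here alone, it is also open whether removing this methyl from compound 2 would cost as much.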